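A few compounds are considered here, and "the series" means these few. Any claim that something is new, unique, unknown or untested is made for them only; others in the source may bear on it.

Compounds measured in a functional assay on the whole organism (6C3HED cells, Mus musculus) for inhibition, at a dose of 150 mg/kg by the oral route; a higher number here means more inhibition at the dose given (going by the name of the read-out), a lower number less inhibition:
Compound 1, `CCc1ccc(S(=O)(=O)NC(=O)Nc2ccc(Cl)cc2)s1`, gives 57%.
Compound 2, `Cc1cc(S(=O)(=O)NC(=O)Nc2ccc(Cl)cc2)sc1C`, gives 42%.

Compound 2 stands lowest of the two numbers shown; its only neighbour is compound 1, and the step of a number 15 percentage points lower from compound 1 to compound 2 (beyond the scatter) sets them apart beyond the scatter. Compound 3, `CCc1sc(S(=O)(=O)NC(=O)Nc2ccc(Cl)cc2)cc1C`, has not yet been measured in this assay. It differs from compound 2 by methyl in place of hydrogen on a saturated chain carbon bound to an aromatic carbon; cut one bond further out, the same difference reads methyl to ethyl, so compound 3 carries the ethyl chain of compound 1 together with the ring methyl of compound 2. For the measured compounds named here, the one measured step that bears on it is a number 15 percentage points lower from compound 1 to compound 2 (beyond the scatter), a modest one, and the change from compound 2 to compound 3 runs partly back toward compound 1. A small rise in this assay is therefore expected, possibly within the scatter. The estimate for compound 3 is 50%, with a range from 30% to 70%, an expected step of a number 8 percentage points higher from compound 2 to compound 3 (within the scatter).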

Compound 3, a percentage reported as inhibition, in the whole organism at one dose (the size of the read-out at that dose, not a potency): 26%
Compound 3: middle estimate off by 24 percentage points, on the high side; the measured number lies below the stated range.
By their numbers in this assay, from the lowest: compound 3; then compound 2; then compound 1.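

In this assay, adding one carbon to the chain does not move the number back toward compound 1: methyl to ethyl on a saturated chain carbon bound to an aromatic carbon comes with a number 16 percentage points lower from compound 2 to compound 3 (beyond the scatter). Methyl in place of hydrogen on an aromatic carbon comes with a number 31 percentage points lower from compound 1 to compound 3 (beyond the scatter), a large step, so the ethyl chain and that added methyl do not combine as separate contributions among these compounds. Nothing at hand accounts for this fall.

As far as these compounds go, it remains open whether a longer chain such as propyl, or a polar group such as an amine or a carboxylic acid, at this place would lower the number further or restore it. From the compounds shown here alone, each compound also has a number at only one oral dose, so whether these steps hold at other doses is unknown.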